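Shortening the Side Chain: Cytotoxicity Expected to Stay Low

The source may hold more compounds than are shown below. What is called first, only, known or untested is meant among the compounds shown, and "the series" means these compounds.

Compound 1 `CC(C)CCn1nc(-c2cccs2)c(O)c(C2=NS(=O)(=O)c3cc(S(C)(=O)=O)ccc3N2)c1=O`: in an ADME assay on Huh-7 cells (Homo sapiens) for cytotoxicity, with a stated time of 72 h (a lower number here means that less compound is tolerated, a higher number that more compound is tolerated), compound 1 gives "not determined" (no result reported), so no result was reported for compound 1.
Compound 2 `CC(C)CCn1nc(-c2ccccc2)c(O)c(C2=NS(=O)(=O)c3cc(NS(C)(=O)=O)ccc3N2)c1=O`: in this assay compound 2 gives > 1000 nM, a limit of the assay.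
Compound 3 `CCC(C)(C)Cn1nc(-c2cccs2)c(O)c(C2=NS(=O)(=O)c3cc(NS(C)(=O)=O)ccc3N2)c1=O`: in this assay compound 3 gives > 1000 nM, also a limit of the assay.

Compound 3 therefore stands at the limit of > 1000 nM in this assay, at which 2 of the 3 values shown sit, not at a number. For the measured compounds named here, no step between two measured compounds is available, so nothing here shows how a change in the side chain moves the read-out. Compound 4 `CC(C)Cn1nc(-c2cccs2)c(O)c(C2=NS(=O)(=O)c3cc(NS(C)(=O)=O)ccc3N2)c1=O` differs from compound 3 by hydrogen in place of ethyl on a saturated chain carbon bound to three saturated chain carbons. Because the limit of > 1000 nM in this assay, at which 2 of the 3 values shown sit, is where compound 3 already sits, a step that the limit leaves unreadable from compound 3 to compound 4 is expected, none beyond the scatter. For compound 4 the half-maximal cytotoxic concentration is estimated at 1500 nM, within 700 nM to 5000 nM, most likely again reported only as a limit.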

Compound 4, half-maximal cytotoxic concentration: > 1000 nM
Compound 4: a limit, no number; the forecaster's own chance of this, stated with the estimate: 85%; the middle value lies beyond the limit too.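

In this assay no step can be read from compound 3 to compound 4, because both results are limits and not numbers: the limit of > 1000 nM in this assay, at which 3 of the 4 values shown sit.

The compounds shown leave open what concentration actually harms these cells, and whether the side chain makes any difference to it.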